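Removing a methoxy group: what the cytotoxicity may do

The source may hold more compounds than are shown below. What is called first, only, known or untested is meant among the compounds shown, and "the series" means these compounds.

Three compounds share one core, an ester-linked aromatic acid joined to a cinnamate-type side chain. Compound 1 `CCOC(=O)/C=C/c1ccc(OC(=O)c2nc(C)c(C)nc2C)c(O)c1` carries a hydroxyl on the aromatic ring, compound 3 `CCOC(=O)/C=C/c1ccc(OC(=O)c2nc(C)c(C)nc2C)c(OC)c1` a methoxy in the same place, and compound 2 `Cc1nc(C)c(C(=O)Oc2ccc(/C=C/C(=O)O)cc2)nc1C` bears a free acid instead of the ethyl ester and no group at that position. In a functional assay on EA.hy 926 cells (Homo sapiens) for cytotoxicity, read by MTT assay, with stated times of 24 h and 12 h, tested at 12.5 uM (a lower number here means a weaker effect, a higher number a stronger effect of the compound at the concentration tested), compound 1 gives 75.7%, compound 3 gives 52.4%, and compound 2 gives 34.2%. Compound 3 thus stands second of the three, with a number 23.3 percentage points lower from compound 1 to compound 3 (beyond the scatter).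

Compound 4 `CCOC(=O)/C=C/c1ccc(OC(=O)c2nc(C)c(C)nc2C)cc1` differs from compound 3 in one spot: hydrogen in place of methoxy on an aromatic carbon. The only measured step touching this position, from hydroxyl to methoxy, lowered the read-out; whether dropping the methoxy altogether returns toward compound 1 or moves further is not shown, since compound 2 also differs in the ester. No clear direction is therefore expected, and the expected step is a number 2.4 percentage points lower from compound 3 to compound 4 (within the scatter). Compound 4 is estimated at 50%, within 30% to 70%.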

Compound 4, a percentage reported as activity, at one concentration (the size of the read-out at that concentration, not a potency): 42.7%
Compound 4: the middle estimate sits 7.3 percentage points above what was measured, and the stated range covers the measured number.
By their numbers in this assay, from the lowest: compounds 2, 4 and 3 (each within the scatter of the next, the first and the last beyond it); then compound 1.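

In this assay, removing the methoxy gives a step that stays small (a number 9.7 percentage points lower from compound 3 to compound 4 (within the scatter)), so methoxy and hydrogen cannot be told apart at this position. Hydroxy does stand apart from hydrogen (a number 33 percentage points lower from compound 1 to compound 4 (beyond the scatter)), which places compound 1 clearly above compound 4 and shows that, among these three groups, the high read-out goes with hydroxy alone. Within the data shown here, compound 4 also isolates the ester for the first time, and replacing the free acid of compound 2 with the ethyl ester makes no change beyond the scatter (a number 8.5 percentage points higher from compound 2 to compound 4 (within the scatter)).

Going by these compounds, what an amine or a longer chain such as ethoxy would do at this aromatic carbon remains open, and so does whether the free acid would behave the same with the hydroxy present. Nothing shown here offers an explanation for the hydroxy result.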